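The compounds below may be only part of what the source reports. "The series", "measured", "known", "first", "only" and "open" are said of these compounds alone.

Measured in a functional assay on A2780 cells (Homo sapiens) for antiproliferative activity, read by CellTiter-Glo, with a stated time of 4 days; on this read-out higher numbers stand for weaker inhibition and lower numbers for stronger inhibition:
Compound 1 `O=C(/C=C/c1cccnc1)Nc1ccc(CN2C(=O)c3ccccc3C2=O)cc1`: "not determined" (no result reported)
Compound 2 `O=C(NCc1cccnc1)Nc1ccc(CNC(=O)c2ccc(CN3CCNCC3)cc2)cc1`: 8 nM
Compound 3 `C[C@H](NC(=O)CC(F)(F)F)c1ccc(NC(=O)[C@H]2C[C@@H]2c2cccnc2)cc1`: 5 nM

Compound 3 gives 5 nM and compound 2 gives 8 nM, two numbers within the usual scatter of each other, while compound 1 offers no number to compare. Compound 4 `C[C@H](NC(=O)c1ccc(C#N)cc1)c1ccc(NC(=O)[C@H]2C[C@@H]2c2cccnc2)cc1` keeps the core of compound 3 but carries 4-cyanophenyl in place of 2,2,2-trifluoroethyl on a carbonyl carbon. Going by the values given here, no measured pair of compounds shows what such an exchange does, so this expectation rests on little. In this assay, no change beyond the scatter is expected, in either direction, and the estimate is a 1.2-fold higher number from compound 3 to compound 4 (0.08 log units; within the scatter). Compound 4 is estimated at 6 nM, with an expected range of 2 nM to 25 nM.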

Compound 4, half-maximal inhibitory concentration: 4 nM
Compound 4: middle estimate off by 1.5-fold (0.18 log units), on the high side; the measured number falls inside the stated range.
By their numbers in this assay, from the lowest: compounds 4, 3 and 2 (each within the scatter of the next).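

In this assay, putting 4-cyanophenyl in place of 2,2,2-trifluoroethyl on a carbonyl carbon gives a 1.3-fold lower number from compound 3 to compound 4 (0.10 log units; within the scatter) and so shows that this position can carry an aromatic ring and more heavy atoms with no measurable difference in the read-out. No data at hand give a reason for this result. Still open, going by these compounds, is whether an amine or a carboxylic acid at this place would read the same. Also open, on these data alone, is whether the ring alone, without its nitrile, would do so.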